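The compounds below may be only part of what the source reports. "The series", "measured", "known", "first", "only" and "open" are said of these compounds alone.

Compound 1 `CNc1nc(OC)nc2c1ncn2C1O[C@H](CO)[C@H](O[C@@H]2OC(CO)[C@H](OP(=O)(O)O)C(OP(=O)(O)O)[C@@H]2O)[C@@H]1OP(=O)(O)O`: 82 nM
Compound 2 `COc1ncnc2c1ncn2C1O[C@H](CO)[C@H](O[C@@H]2OC(CO)[C@H](OP(=O)(O)O)C(OP(=O)(O)O)[C@@H]2O)[C@@H]1OP(=O)(O)O`: 19 nM

Of the compounds shown here, two have been measured in a functional assay (Hepatocyte) with Rattus norvegicus as the target; a higher number here means that more compound is needed for the effect, a lower number that less compound is needed. Compound 2 stands at the lowest of the two numbers; compound 1 gives a higher number, and that gap lies beyond the usual scatter. Compound 3 `Nc1ncnc2c1ncn2C1O[C@H](CO)[C@H](O[C@@H]2OC(CO)[C@H](OP(=O)(O)O)C(OP(=O)(O)O)[C@@H]2O)[C@@H]1OP(=O)(O)O` has not yet been measured. It differs from compound 2 in a single place: amino in place of methoxy on an aromatic carbon. Among the compounds with values here, no pair of measured compounds isolates this change, so nothing measured shows how it acts here. A modest downward step, not a large one, is expected for compound 3, namely a 1.9-fold lower number from compound 2 to compound 3 (0.28 log units; within the scatter). Compound 3 is estimated to give 10 nM, within a range from 3 nM to 40 nM.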

Compound 3, half-maximal effective concentration: 14 nM
Estimate against measurement, compound 3: 1.4-fold (0.15 log units) below, within the range that was stated.
By their numbers in this assay, from the lowest: compounds 3 and 2 (each within the scatter of the next); then compound 1.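

In this assay, amino in place of methoxy on this aromatic carbon gives a 1.4-fold lower number from compound 2 to compound 3 (0.13 log units; within the scatter) and so does not separate the two groups. At this position, one nitrogen with a hydrogen-bond donor can therefore stand in for the carbon and oxygen of methoxy without a readable shift in the number. Nothing available gives a reason for this result.

Still open, going by these compounds, is how a plain hydrogen, a chlorine atom or a larger group such as dimethylamino or ethoxy would behave at this same carbon.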